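A few compounds are considered here, and "the series" means these few. Any claim that something is new, unique, unknown or untested is made for them only; others in the source may bear on it.

Working notes, values from a physicochemical assay for solubility, at pH 7.4; a higher number here means a more soluble compound, a lower number a less soluble compound:

- compound 1 `CNc1nc(NC2(C#N)CCCCCC2)nc(-n2cncn2)n1`: 9 ug/mL
- compound 2 `CCCC(C#N)(CC)Nc1nc(NC)nc(-n2cncn2)n1`: 76 ug/mL

Compound 2, at 76 ug/mL, stands highest of the two measured compounds, and the gap down to compound 1 lies beyond the scatter. Compound 3 `CCC(C)(C#N)Nc1nc(NC)nc(-n2cncn2)n1` is the next to read in this assay. Against compound 2 it differs thus: hydrogen in place of ethyl on a saturated chain carbon, two bonds along the chain from a nitrogen on an aromatic ring and a triple-bonded carbon. Cut one bond further out, this reads propyl to methyl.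

Going by the values given here, no measured pair differs in one place only, so the size of this step has no direct precedent. Compound 1, the larger structure of the two, gives the lower value, 9 ug/mL, which is thin support for an upward direction. The expected change is a moderate rise, a 1.8-fold higher number from compound 2 to compound 3 (0.27 log units; within the scatter), which may not clear the scatter. For compound 3 the estimated value is 140 ug/mL, with an expected range of 60 ug/mL to 350 ug/mL.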

Compound 3, solubility: 50 ug/mL
For compound 3 the middle estimate is 2.8-fold (0.45 log units) above the measured one, outside the stated range (below it).
By their numbers in this assay, from the lowest: compound 1; then compounds 3 and 2 (each within the scatter of the next).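

In this assay, the series now has its first step that differs in one place: hydrogen in place of ethyl on this saturated chain carbon gives a 1.5-fold lower number from compound 2 to compound 3 (0.18 log units; within the scatter), which the usual scatter covers. Read one bond further out, propyl to methyl at this position leaves compound 2 and compound 3 indistinguishable, so this single pair shows no measurable dependence on the length of this chain. No measured property available here bears on this result.

On these data alone, the effect of a longer chain or an amine on this saturated chain carbon remains open, as does whether the same change would behave alike with the rest of the structure altered. Compound 1 differs from compound 2 and compound 3 in more than one place, so its value cannot be assigned to any single part of the structure.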